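Moving a Three-Carbon Amide Substituent from Branched to Straight

The compounds below may be only part of what the source reports. "The series", "measured", "known", "first", "only" and "open" are said of these compounds alone.

Three analogues share one core. Compound 1 `NC(=O)/C=C1\CCc2cc(Cl)ccc21` gives 29% in a functional assay on the whole organism with Rattus norvegicus as the target, at a dose of 20 mg/kg by the oral route; a higher number here means more inhibition at the dose given (going by the name of the read-out), a lower number less inhibition. Compound 2 `NC(=O)/C=C1\CCc2c(Cl)cccc21` gives 58% in this assay. Compound 3 `CC(C)NC(=O)/C=C1\CCc2ccc(F)cc21` gives 71% in this assay, the highest of the three numbers, with compound 2 closest and compound 1 furthest away, both gaps lying beyond the usual scatter.

Compound 4 `CCCNC(=O)/C=C1\CCc2ccc(F)cc21` has not yet been measured in this assay. It differs from compound 3 by propyl in place of isopropyl on an amide-type nitrogen. For the measured compounds named here, no measured pair shows what this change does, so the expected step from compound 3 to compound 4 is set at a number 5 percentage points lower from compound 3 to compound 4 (within the scatter), which is none beyond the scatter. Compound 4 is therefore expected to give about 66%, estimated between 46% and 86%.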

Compound 4, a percentage reported as inhibition, in the whole organism at one dose (the size of the read-out at that dose, not a potency): 36%
Compound 4: middle estimate off by 30 percentage points, on the high side; measured number below the stated range.
By their numbers in this assay, from the lowest: compounds 1 and 4 (each within the scatter of the next); then compound 2; then compound 3.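

Swapping isopropyl for propyl on the amide-type nitrogen gives, in this assay, a number 35 percentage points lower from compound 3 to compound 4 (beyond the scatter), so at this position the way the same three carbons are joined matters, not their number alone. Nothing available explains this step.

On these data alone, whether a longer chain such as butyl, or a cyclopropyl group, on this nitrogen would sit nearer compound 3 or compound 4 remains open. So does whether the same swap would have a similar effect on a core carrying chlorine in place of fluorine.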